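Fluoro on the phenyl: from compound 3 to compound 4

The source may report more compounds than this note shows. Statements on the series, on what has been measured and on what is new or still open speak of the compounds shown alone.

Compound 1 `Cc1c(C(=O)Nc2ccc(Oc3ccnc4[nH]ccc34)c(F)c2)nnn1-c1ccccc1`: 290 nM
Compound 2 `Cc1c(C(=O)Nc2ccc(Oc3ccnc4[nH]ccc34)c(F)c2)nnn1-c1ccccc1F`: 180 nM
Compound 3 `Cc1c(C(=O)Nc2ccc(Oc3ccnc4[nH]ccc34)cc2)nnn1-c1ccccc1`: 350 nM

In a functional assay on HT-29 cells (Homo sapiens) for cytotoxicity, read by MTT assay, with a stated time of 72 h (a higher number here means a weaker inhibitor, a lower number a stronger inhibitor), compound 3 gives the highest of the three numbers, but its distance to compound 1, a 1.2-fold higher number from compound 1 to compound 3 (0.08 log units; within the scatter), lies within the scatter, and compound 2 with 180 nM is likewise within the scatter of compound 3. Compound 4 `Cc1c(C(=O)Nc2ccc(Oc3ccnc4[nH]ccc34)cc2)nnn1-c1ccccc1F` differs from compound 3 by fluoro in place of hydrogen on an aromatic carbon. For the measured compounds named here, one measured step bears on this change: the same fluoro for hydrogen on the core of compound 1 gave a 1.6-fold lower number from compound 1 to compound 2 (0.21 log units; within the scatter). Compound 4 is therefore expected to show at most a small step towards a lower number, not beyond the scatter, a 1.5-fold lower number from compound 3 to compound 4 (0.18 log units; within the scatter). Compound 4 is estimated at 230 nM, with a range from 110 nM to 480 nM.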

Compound 4, half-maximal inhibitory concentration: 360 nM
Compound 4: middle estimate off by 1.6-fold (0.19 log units), on the low side; the measured number falls inside the stated range.
By their numbers in this assay, from the lowest: compounds 2, 1, 3 and 4 (each within the scatter of the next).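

In this assay, phenyl to 2-fluorophenyl now has a reading on a second core, a 1.0-fold higher number from compound 3 to compound 4 (0.01 log units; within the scatter), so on neither core does this fluoro move the number beyond the scatter. The two readings agree within the scatter: the same change on two cores in this assay, a 1.6-fold lower number (0.21 log units; within the scatter) from compound 1 to compound 2 and a 1.0-fold higher number (0.01 log units; within the scatter) from compound 3 to compound 4, 1.7-fold (0.22 log units) apart, within the scatter of two such steps Hydrogen in place of fluoro on the shared core also stays within the scatter when the 2-fluorophenyl is present, a 2.0-fold higher number from compound 2 to compound 4 (0.30 log units; within the scatter), and this change too agrees across the two cores: the same change on two cores in this assay, a 1.2-fold higher number (0.08 log units; within the scatter) from compound 1 to compound 3 and a 2.0-fold higher number (0.30 log units; within the scatter) from compound 2 to compound 4, 1.7-fold (0.22 log units) apart, within the scatter of two such steps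

The compounds shown leave open whether a larger group at this position, such as a methoxy, an amine or a carboxylic acid, would move the number beyond the scatter.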